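Cytotoxicity notes on bicyclic amines with thienylmethyl substituents

The compounds below may be only part of what the source reports. "The series", "measured", "known", "first", "only" and "open" are said of these compounds alone.

Measured compounds:
compound 1, `Cc1ccsc1CN[C@@H]1C[C@H]2C[C@@H]([C@H]1C)C2(C)C`, 10000 nM
compound 2, `CCCCc1ccsc1CN[C@@H]1C[C@H]2C[C@@H]([C@H]1C)C2(C)C`, 25000 nM
compound 3, `C[C@H]1[C@H](NCc2sccc2-c2ccsc2)C[C@H]2C[C@@H]1C2(C)C`, 12500 nM

In an ADME assay on MDCK cells (Canis lupus familiaris) for cytotoxicity, read by microscopy, with a stated time of 48 h (a lower number here means that less compound is tolerated, a higher number that more compound is tolerated), compound 1 holds the lowest of the three numbers. Within the data shown here, its nearest neighbour is compound 3, with a 1.3-fold higher number from compound 1 to compound 3 (0.10 log units; within the scatter); its furthest is compound 2, with a 2.5-fold higher number from compound 1 to compound 2 (0.40 log units; beyond the scatter), the only step in the set that leaves the scatter. Between compound 2 and compound 3 the step is a 2.0-fold lower number from compound 2 to compound 3 (0.30 log units; within the scatter).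

Compound 4, `C[C@H]1[C@H](NCc2nccs2)C[C@H]2C[C@@H]1C2(C)C`, has not yet been measured. Its change from compound 1 is 1,3-thiazol-2-yl in place of 3-methylthiophen-2-yl on a saturated chain carbon bound to an amine nitrogen. Among the measured compounds shown here, no measured step touches this kind of change: the step from compound 1 to compound 2 adds a chain on the ring, and the step from compound 1 to compound 3 exchanges a methyl for a second ring while staying within the scatter. For the measured compounds named here, the one step beyond the scatter follows an addition of atoms, whereas compound 4 loses atoms relative to compound 1. Going by the values given here, with no comparable step to lean on, the expected step of no change at the digits printed from compound 1 to compound 4 (within the scatter) in this assay is none beyond the scatter. Compound 4 is therefore estimated at 10000 nM, within 5000 nM to 25000 nM.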

Compound 4, minimum cytotoxic concentration: > 100000 nM
Compound 4 ended at the assay's limit; the forecaster's own chance of this, stated with the estimate: 20%; middle value at least 10-fold (1.00 log units) away from the limit.
By their numbers in this assay, from the lowest: compounds 1, 3 and 2 (each within the scatter of the next, the first and the last beyond it). At a limit, above all of these: compound 4.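

In this assay, the group on the saturated chain carbon bound to an amine nitrogen is where the series now shows its largest step: 1,3-thiazol-2-yl in place of 3-methylthiophen-2-yl gives an at least 10-fold higher number from compound 1 to compound 4 (1.00 log units; beyond the scatter). Among these compounds, compound 4 stands at > 100000 nM, which is a limit of the assay: the limit of > 100000 nM in this assay, at which 1 of the 4 values shown sits. Compound 1, compound 2 and compound 3 all carry a five-membered aromatic ring with 1 hetero atom at this place, so compound 4 gives the first reading with a ring holding 2 hetero atoms there.

The change to compound 4 alters the ring and removes the methyl in one step, and a plain thiophen-2-yl on this carbon would separate the two. From the compounds shown here alone, how a six-membered ring such as phenyl or pyridin-2-yl would read at this place also stays open.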